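A nitrile in place of a methyl group

The source may hold more compounds than are shown below. What is called first, only, known or untested is meant among the compounds shown, and "the series" means these compounds.

Values in a functional assay on MT4 cells (Homo sapiens) for cytotoxicity; a higher number here means a weaker inhibitor, a lower number a stronger inhibitor:
Compound 1 `N#Cc1c(N)cccc1Sc1ccccc1`: 168000 nM
Compound 2 `N#Cc1c(N)cccc1Sc1cccc(N)c1`: 168000 nM
Compound 3 `Cc1ccccc1[S+]([O-])c1cccc(N)c1C#N`: > 200000 nM (a limit)
Compound 4 `N#Cc1ccccc1[S+]([O-])c1cccc(N)c1C#N`: not yet measured

Compound 3 has no number of its own and stands at the limit of > 200000 nM in this assay, at which 1 of the 3 values shown sits. Compound 4 differs from it in one place, (cyano in place of methyl on an aromatic carbon), with cyano in place of methyl on an aromatic carbon, ortho to a large group. For the measured compounds named here, only one measured step exists, and it involves a different change, amino in place of hydrogen on an aromatic carbon. That step shows no change at the digits printed from compound 1 to compound 2 (within the scatter). The expected step is therefore a number no higher from compound 3 to compound 4 (the limit leaves the size open), with no shift beyond the scatter anticipated in this assay. Compound 4 is expected at about 200000 nM, with an estimated range of 90000 nM to 400000 nM.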

Compound 4, half-maximal inhibitory concentration: > 200000 nM
Compound 4: no number, only a limit; the forecaster's own chance of this, stated with the estimate: 60%; the middle value lies on the limit itself.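

In this assay, for the compounds shown here, compound 3 and compound 4 each give only a limit, and no step between them can be read. The compounds shown leave open what cyano in place of methyl on an aromatic carbon does to the read-out.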